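A few compounds are considered here, and "the series" means these few. Any claim that something is new, unique, unknown or untested is made for them only; others in the source may bear on it.

Working notes on the benzofuran series in an ADME assay on microsomes from liver (Homo sapiens) for metabolic stability, with a stated time of 10 min; on this read-out lower numbers stand for a less stable compound and higher numbers for a more stable compound.

Compound 1 `COc1cc(OCc2cccc(CCc3ccccc3)c2)c2cc(-c3cn4nc(OC)sc4n3)oc2c1` is the reference point. In this assay compound 1 gives 99%, which is the highest of the two numbers recorded so far. The nearest measured neighbour is compound 3 `Cc1nn2cc(-c3cc4ccccc4o3)nc2s1`, which in this assay gives 20%; the gap between compound 1 and compound 3 is well beyond the scatter of repeated measurements. Compound 2 `CS(=O)(=O)c1nn2cc(-c3cc4ccccc4o3)nc2s1` was also prepared, but for this assay compound 2 is reported as "not determined" (no result reported). Going by the values given here, no pair of measured compounds differs in a single place, so no isolated step from the measured set can be used as a guide.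

The next compound, compound 4 `COc1cc(OCc2cccc(OCc3ccccc3)c2)c2cc(-c3cn4nc(OC)sc4n3)oc2c1`, differs from compound 1 in one place: benzyloxy in place of phenethyl on an aromatic carbon. Compound 1 already sits close to the top of the read-out, so any movement upward would be small.

For compound 4 the expectation is a step of a number 9 percentage points lower from compound 1 to compound 4 (within the scatter), that is, none beyond the scatter, because compound 1 gives 99% and the shared core is unchanged. Compound 4 is therefore estimated at 90%, with a range from 70% to 100%.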

Compound 4, percent of the compound remaining: 85%
Compound 4: the middle estimate sits 5 percentage points above what was measured, and the stated range covers the measured number.
By their numbers in this assay, from the lowest: compound 3; then compound 4; then compound 1.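

In this assay, going by these compounds alone, the change gives a number 14 percentage points lower from compound 1 to compound 4 (beyond the scatter) and this is the first single-place comparison, so it shows that the read-out responds to what stands on this aromatic carbon, meta to a large group. Benzyloxy and phenethyl both count 8 heavy atoms and both carry a six-membered aromatic ring of carbon only, so an exchange that keeps this count and ring and differs by one carbon for one oxygen, with one hydrogen-bond acceptor added, is enough to give a modest step beyond the scatter. With compound 4 at 85% on this read-out, the step remains modest, and no available measurement bears on the reason for it.

Going by these compounds, a single pair cannot show whether other groups at this aromatic carbon would give a larger step, a smaller step or none, and how a methoxy group, an amine or a carboxylic acid would read here remains open. On these data alone, it also remains open whether the same exchange would give a comparable step on a different core, or whether a longer chain ending in the same phenyl ring would behave like phenethyl or like benzyloxy.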